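A few compounds are considered here, and "the series" means these few. Any claim that something is new, unique, unknown or untested is made for them only; others in the source may bear on it.

Compound 1, `O=C1OCC[C@@H]1NC(=S)SCCOc1ccccc1[N+](=O)[O-]`: 24000 nM
Compound 2, `O=C(CNc1ccccc1F)N[C@H]1CCOC1=O`: > 64000 nM

Of the compounds shown here, two have so far been measured in a functional assay on PC-3 cells (Homo sapiens) for antiproliferative activity, read by MTT assay, with a stated time of 72 h; on this read-out higher numbers stand for weaker inhibition and lower numbers for stronger inhibition. Compound 1 (`O=C1OCC[C@@H]1NC(=S)SCCOc1ccccc1[N+](=O)[O-]`) gives 24000 nM there. Compound 2 (`O=C(CNc1ccccc1F)N[C@H]1CCOC1=O`) does not give a number at all: its result in this assay is > 64000 nM, which is a limit of the assay, namely (the limit of > 64000 nM in this assay, at which 1 of the 2 values shown sits). Compound 2 therefore stands at the weak end of what this read-out can report. Among the measured compounds shown here, the two measured compounds differ in more than one place, so no single step between them is counted, and nothing measured shows how one change alone moves the result.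

Compound 3 (`O=C(CNc1ccccc1Cl)N[C@H]1CCOC1=O`) has not yet been measured. It differs from compound 2 by chloro in place of fluoro on an aromatic carbon, on an aromatic carbon of a six-membered aromatic ring of carbon only, ortho to a large group. With no measured step of this kind in this assay, the expectation for compound 3 is a change no larger than the usual scatter, in no fixed direction. Compound 3 is thus expected to stay near the limit, with an estimated step of a number no higher from compound 2 to compound 3 (the limit leaves the size open). The estimate for compound 3 is 64000 nM, expected to lie between 20000 nM and 200000 nM.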

Compound 3, half-maximal inhibitory concentration: > 64000 nM
Compound 3 gave a limit, no number (the forecaster's own chance of this, stated with the estimate: 70%); the middle value sits exactly at the limit.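

Compound 2 and compound 3 both give a limit rather than a number in this assay, so no step can be read between them: the limit of > 64000 nM in this assay, at which 2 of the 3 values shown sit.

The compounds shown leave open whether chloro in place of fluoro on an aromatic carbon changes the result in this assay at all, and in which direction.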